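The source may report more compounds than this note shows. Statements on the series, on what has been measured and on what is new or still open speak of the compounds shown alone.

Working notes on the series. The shared core is that of compound 1 `COc1cccc(NC2=CC(=O)c3c(nc4n3[C@H]3OC[C@@H](O)[C@H]3OC4)C2=O)c1`. Among the measured compounds shown here, in a functional assay on ECa-109 cells for inhibition, with ECa-109 cell line (Homo sapiens) as the target, read by sulforhodamine B assay (on this read-out lower numbers stand for stronger inhibition and higher numbers for weaker inhibition), compound 1 gives 3340 nM, and this is the only numerical value in the set so far. Compound 2 `O=C1C=C(NC2CCCCC2)C(=O)c2c1nc1n2[C@H]2OC[C@@H](O)[C@H]2OC1` in this assay gives > 16000 nM, which is a limit of the assay and not a number. The set thus contains (the limit of > 16000 nM in this assay, at which 1 of the 2 values shown sits). For the measured compounds named here, no step between two measured compounds that differ in a single place is available, so no measured step size can be quoted.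

Compound 3 `O=C1C(N2CCCC2)=CC(=O)c2c1nc1n2[C@H]2OC[C@@H](O)[C@H]2OC1` remains to be measured. Its change from compound 1 is pyrrolidin-1-yl in place of (3-methoxyphenyl)amino on a double-bonded ring carbon: the single hydrogen-bond donor and the six-membered aromatic ring leave, and a five-membered non-aromatic ring with one hetero atom enters. Compound 2, which likewise carries no aromatic ring, reaches only the limit > 16000 nM. For compound 3 a loss in this assay beyond the usual scatter is expected. The estimate for compound 3 is 10000 nM, in the range 3300 nM to 16000 nM. This corresponds to an expected step of a 3.0-fold higher number from compound 1 to compound 3 (0.48 log units; beyond the scatter).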

Compound 3, half-maximal inhibitory concentration: > 16000 nM
Compound 3 gave a limit, no number (the forecaster's own chance of this, stated with the estimate: 40%); at least 1.6-fold (0.20 log units) between middle value and limit.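

In this assay, among the compounds shown here, pyrrolidin-1-yl in place of (3-methoxyphenyl)amino on a double-bonded ring carbon gives an at least 4.7-fold higher number from compound 1 to compound 3 (0.68 log units; beyond the scatter), the first measured step at this position. The value of compound 3, > 16000 nM, is a limit of the assay and not a number. The step therefore sets a floor on the loss from this change and gives no size for it, and compound 1 is still the only compound in the set with a number: the limit of > 16000 nM in this assay, at which 2 of the 3 values shown sit.

The compounds shown leave open which part of the change goes with the loss, since the hydrogen-bond donor and the six-membered aromatic ring leave together and the entering ring differs from the leaving group in size as well. A phenylamino group without the methoxy, a benzylamino group or an N-methyl-N-phenylamino group at this position would bear on that question, as would other placements of the methoxy on the aromatic ring of compound 1.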